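The compounds below may be only part of what the source reports. "The series", "measured", "known", "first", "only" and "open" are said of these compounds alone.

In a functional assay on MCF7 cells (Homo sapiens) for antiproliferative activity, read by MTT assay, with a stated time of 48 h (a lower number here means a stronger inhibitor, a higher number a weaker inhibitor), compound 1 `COc1ccc(C(=O)c2ccc(OC)c3c2C=CC(C)(C)O3)c(NC(=O)CN)c1` gives 1250 nM. Compound 2 `CNCC(=O)Nc1cc(OC)ccc1C(=O)c1ccc(OC)c2c1C=CC(C)(C)O2` carries one change, (methyl in place of hydrogen on an amine nitrogen), and in this assay compound 2 gives 3040 nM, so that the step of a 2.4-fold higher number from compound 1 to compound 2 (0.39 log units; beyond the scatter). Compound 3 `C=C(c1cc(OC)c(OC)c(OC)c1)c1ccc(OC)cc1NC(=O)CN` is built on a different core; how the two cores differ is not broken down here. In this assay, among the compounds with values here, compound 3 gives 190 nM, the lowest of the three numbers so far. Within the data shown here, compound 4 `C=C(c1cc(OC)c(OC)c(OC)c1)c1ccc(OC)cc1NC(=O)CNC` has not been measured yet; it differs from compound 3 by methyl in place of hydrogen on an amine nitrogen, the same change at the same place as the one that separates compound 1 from compound 2. The step of a 2.4-fold higher number from compound 3 to compound 4 (0.37 log units; beyond the scatter) is expected to be of similar size because the earlier example gave a 2.4-fold higher number from compound 1 to compound 2 (0.39 log units; beyond the scatter), although this rests on a single pair. Compound 4 is therefore estimated at 450 nM, with a likely range from 200 nM to 1000 nM.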

Compound 4, half-maximal inhibitory concentration: 240 nM
The estimate for compound 4 lay 1.9-fold (0.27 log units) above the measured number, within the range that was stated.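

On the core of compound 3, methyl in place of hydrogen on the amine nitrogen gives a 1.3-fold higher number from compound 3 to compound 4 (0.10 log units; within the scatter) in this assay, so on this core the change has no effect that can be told apart from repeat-measurement scatter. Set beside the step on the other core, this step does not differ from it by more than the scatter allows: the same change on two cores in this assay, a 2.4-fold higher number (0.39 log units; beyond the scatter) from compound 1 to compound 2 and a 1.3-fold higher number (0.10 log units; within the scatter) from compound 3 to compound 4, 1.9-fold (0.28 log units) apart, within the scatter of two such steps. The two pairs are consistent with the change carrying from one core to the other, but two pairs cannot establish this, and they leave its true size unsettled.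

Still open, going by these compounds, is how an ethyl group or a second methyl on this nitrogen, or a longer chain in place of the aminomethyl, would behave in this assay. On these data alone, whether either step would hold in other cell lines also remains open.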